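Phenyl on the saturated ring of a fatty acid receptor agonist

The source may hold more compounds than are shown below. What is called first, only, known or untested is meant among the compounds shown, and "the series" means these compounds.

Measured compounds:
compound 1 `Cc1ccccc1Cc1ccc(N2CCC[C@H]2CC(=O)O)cc1`: 150 nM
compound 2 `Cc1ccccc1Cc1ccc(N2CC[C@H](C)[C@H]2CC(=O)O)cc1`: 120 nM

In a functional assay on cells for agonist activity at Free fatty acid receptor 1 (Homo sapiens), read by FLIPR and calcium flux, with a stated time of 100 s (a lower number here means that less compound is needed, a higher number that more compound is needed for the effect), compound 1 gives 150 nM, the highest of the two numbers recorded; its nearest neighbour is compound 2, which gives 120 nM. Going by the values given here, the only step measured so far is a 1.3-fold lower number from compound 1 to compound 2 (0.10 log units; within the scatter), so a small substituent on that carbon changed nothing beyond the scatter. Compound 3 `Cc1ccccc1Cc1ccc(N2C[C@@H](c3ccccc3)C[C@H]2CC(=O)O)cc1` is not yet measured. It differs from compound 1 by phenyl in place of hydrogen on a saturated ring carbon. Among the compounds with values here, the methyl step bears on it only loosely: it shows the ring tolerates a small group, but a phenyl is much larger, and no measured step tells what a group of that size does there. The estimate therefore stays near compound 1 with a wide range. Compound 3 is expected at 150 nM (range 40 nM to 600 nM), a step of no change at the digits printed from compound 1 to compound 3 (within the scatter) that is expected to stay within the scatter.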

Compound 3, half-maximal effective concentration: > 17000 nM
Compound 3: only a limit was reported (the forecaster's own chance of this, stated with the estimate: 5%); at least 110-fold (2.05 log units) between middle value and limit.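

In this assay, going by these compounds alone, the step of an at least 110-fold higher number from compound 1 to compound 3 (2.05 log units; beyond the scatter) is the first beyond the scatter, while the only earlier step of a 1.3-fold lower number from compound 1 to compound 2 (0.10 log units; within the scatter) stayed within it. A phenyl on the saturated ring carbon two ring bonds from the ring nitrogen, and two ring bonds from the ring atom that bears the carboxymethyl group, is therefore not tolerated in the way the earlier methyl change was. The figure for compound 3 is a limit and not a number: the limit of > 17000 nM in this assay, at which 1 of the 3 values shown sits.

What a methyl, a fluorine or a hydroxyl would do on this same carbon stays open, so the compounds shown cannot separate the effect of the phenyl from that of any substituent there. Also open, on these data alone, is whether a phenyl with the opposite arrangement at this carbon would behave in the same way.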